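The source may report more compounds than this note shows. Statements on the series, on what has been measured and on what is new or still open speak of the compounds shown alone.

In a functional assay on SH-SY5Y cells (Homo sapiens) for cytotoxicity, read by MTT assay, with a stated time of 48 h (on this read-out lower numbers stand for stronger inhibition and higher numbers for weaker inhibition), compound 2, `COc1ccc(/C=C/C(=O)/C=C/c2nc3ccccc3n2C)cc1O`, gives 4800 nM. Compound 1, `COc1cc(/C=C/C(=O)/C=C/c2nc3cc(Cl)ccc3n2C)ccc1O`, gives 4700 nM, within the scatter of that value, while compound 3, `COc1ccc(/C=C/C(=O)/C=C/c2nc3c(C)cccc3n2C)cc1O`, gives 19100 nM, the highest number of the three. The next compound to consider is compound 4, `COc1ccc(/C=C/C(=O)/C=C/c2nc3cc(Cl)ccc3n2C)cc1O`, which is derived from compound 2 by one change: chloro in place of hydrogen on an aromatic carbon.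

Among the measured compounds shown here, no measured step shows this exact change. The nearest single change is methyl in place of hydrogen on an aromatic carbon, which gave a 4.0-fold higher number from compound 2 to compound 3 (0.60 log units; beyond the scatter). That step is modest but beyond the scatter, and it involves a different group, so it offers only a loose warning that substitution on this ring can shift the number. For the measured compounds named here, compound 1, the one measured compound bearing a chloro, stands at 4700 nM, although no single-change step connects it to compound 2. On this evidence, little movement is expected in this assay, with no step beyond the scatter and a slight lean towards a lower number. The estimated step is a 1.1-fold lower number from compound 2 to compound 4 (0.06 log units; within the scatter). For compound 4 the expected value is 4200 nM, with an estimated range from 1900 nM to 9500 nM.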

Compound 4, half-maximal inhibitory concentration: 4800 nM
Estimate against measurement, compound 4: 1.1-fold (0.06 log units) below; the measured number falls inside the stated range.
By their numbers in this assay, from the lowest: compounds 1, 2 and 4 (each within the scatter of the next); then compound 3.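

In this assay, chloro in place of hydrogen on an aromatic carbon gives no change at the digits printed from compound 2 to compound 4 (within the scatter), so this place on the six-membered aromatic ring of carbon only, meta to a fused ring and para to a fused ring, accepts a chloro without any shift in the number. Among the compounds shown here, the earlier compounds showed only that the number can move with substitution on this ring, as in a 4.0-fold higher number from compound 2 to compound 3 (0.60 log units; beyond the scatter), and the new step shows that such substitution need not move it; since the methyl of compound 3 and the chloro of compound 4 differ both in the group and in where it sits, the contrast between these two steps cannot be assigned to either difference alone. Nothing available here offers an explanation for the flat step at this place.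

The compounds shown leave open whether a methyl at this same place would behave like the chloro or like the methyl of compound 3. They also leave open whether a larger or differently built group here, such as an amine, a carboxylic acid or a longer alkyl chain, would leave the number just as unchanged.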